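The compounds below may be only part of what the source reports. "The series", "measured", "known", "first", "only" and "open" are said of these compounds alone.

In a functional assay on A-375 cells (Homo sapiens) for inhibition, read by MTT assay, with a stated time of 120 h (a higher number here means a weaker inhibitor, a lower number a stronger inhibitor), compound 3 (`CNC(=O)/C(C)=C/c1ccc(NC(=O)Nc2ccc(Cl)c(C(F)(F)F)c2)cc1`) is known only as a limit, > 50000 nM. Compound 1 (`C/C(=C\c1ccc(NC(=O)Nc2ccc(Cl)c(C(F)(F)F)c2)cc1)C(=O)NC(C)c1ccccc1`) is also known only as a limit, > 50000 nM. Both rest on (the limit of > 50000 nM in this assay, at which 2 of the 3 values shown sit). Compound 2 (`CC(NC(=O)/C=C/c1ccc(NC(=O)Nc2ccc(Cl)c(C(F)(F)F)c2)cc1)c1ccccc1`) alone gives a number, 20800 nM. Compound 4 (`CNC(=O)/C=C(\C)c1ccc(NC(=O)Nc2ccc(Cl)c(C(F)(F)F)c2)cc1`) has the same atoms as compound 3, joined differently: 1-methyl-2-(methylcarbamoyl)ethenyl in place of 2-(methylcarbamoyl)prop-1-en-1-yl on an aromatic carbon. Going by the values given here, both ends of the only measured step that bears on this change, a step that the two limits leave unreadable from compound 1 to compound 3, are limits, so it offers no size to carry over. With no measured size to go on, no shift beyond the scatter is expected in either direction. The expected size of an at least 1.1-fold lower number from compound 3 to compound 4 (0.04 log units; that floor lies within the scatter) is therefore small. Compound 4 is estimated at 45000 nM, with an expected range of 15000 nM to 100000 nM.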

Compound 4, half-maximal inhibitory concentration: > 50000 nM
Compound 4 gave a limit, no number (the forecaster's own chance of this, stated with the estimate: 65%); middle value at least 1.1-fold (0.04 log units) from the limit.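

Compound 3 and compound 4 are both limits, not numbers, so the step between them cannot be read: the limit of > 50000 nM in this assay, at which 3 of the 4 values shown sit. The compounds shown leave open whether, in this assay, 1-methyl-2-(methylcarbamoyl)ethenyl and 2-(methylcarbamoyl)prop-1-en-1-yl differ at all.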